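The source may report more compounds than this note shows. Statements on the series, on what has been measured and on what is new or still open speak of the compounds shown alone.

Compound 3 `CC(C)CCN1C(=O)C(C2=NS(=O)(=O)c3cc(NS(C)(=O)=O)ccc3N2)=C(O)[C@H]2CCC[C@H]21` gives 0.383 h in an in vitro ADME assay on microsomes from liver (Homo sapiens) for metabolic stability (on this read-out higher numbers stand for a longer-lived compound and lower numbers for a shorter-lived compound), the highest of the two numbers in hand. Compound 2 `CC(C)CCN1C(=O)C(C2=NS(=O)(=O)c3cc(NS(C)(=O)=O)ccc3N2)=C(O)C2CCCC21` gives 0.167 h in this assay; a 2.3-fold higher number from compound 2 to compound 3 (0.36 log units; beyond the scatter), a step on which the fact that one of compounds 2 and 3 is drawn with a defined configuration and the other without, at the place where they differ bears. Compound 1 `CS(=O)(=O)Nc1ccc2c(c1)S(=O)(=O)N=C(C1=C(O)[C@H]3CCC[C@H]3N(Cc3ccc(F)c(F)c3)C1=O)N2` gives > 1 h in this assay, which is a limit of the assay and not a number. From there, an at least 2.6-fold lower number from compound 1 to compound 3 (0.41 log units; beyond the scatter); the limit of > 1 h in this assay, at which 1 of the 3 values shown sits, bears on the size of that step. Compound 4 `CS(=O)(=O)Nc1ccc2c(c1)S(=O)(=O)N=C(C1=C(O)[C@H]3CCC[C@H]3N(Cc3ccc(F)c(Cl)c3)C1=O)N2` differs from compound 3 by 3-chloro-4-fluorophenyl in place of isobutyl on a saturated chain carbon bound to an amide-type nitrogen in a ring. This is close to the reverse of the step from compound 1 to compound 3, with 3-chloro-4-fluorophenyl in place of 3,4-difluorophenyl, so a rise of roughly that size is expected in this assay. For compound 4 the step of a 3.1-fold higher number from compound 3 to compound 4 (0.50 log units; beyond the scatter) is expected. Compound 4 is therefore estimated at 1.2 h in this assay, between 0.6 h and 3 h, with a fair chance that only a limit is reported.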

Compound 4, half-life: > 1 h
Compound 4: no number, only a limit (the forecaster's own chance of this, stated with the estimate: 60%); the middle value does not contradict the limit.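

In this assay, the change from isopentyl to 3-chloro-4-fluorobenzyl gives an at least 2.6-fold higher number from compound 3 to compound 4 (0.41 log units; beyond the scatter), so the rise at this position is not confined to the 3,4-difluorophenyl of compound 1. Compound 4 gives > 1 h, which is a limit of the assay and not a number. The step from compound 1 to compound 4, chloro in place of fluoro on an aromatic carbon, cannot be read: the limit of > 1 h in this assay, at which 2 of the 4 values shown sit.

As far as these compounds go, whether the rise needs the halogens or only the aromatic ring stays open. An unsubstituted benzyl at this position would separate the two.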